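The source may hold more compounds than are shown below. What is called first, only, known or untested is meant among the compounds shown, and "the series" means these compounds.

Of the compounds shown here, two have been measured in a functional assay on cells (Cancer cell lines, Homo sapiens) for cytotoxicity, with a stated time of 48 h; a higher number here means a weaker inhibitor of growth, a lower number a stronger inhibitor of growth. Compound 1 `COc1ccc2c(c1)/C(=C\c1c(Cl)n(Cc3cc(OC)c(OC)c(OC)c3)c3cc(C)c(OC)cc13)C(=O)N2` gives 10200 nM in this assay. Compound 2 `O=C1Nc2ccc(Cl)cc2/C1=C\c1c(Cl)n(CCCc2ccccc2)c2ccccc12` gives 2190 nM in this assay. On these two numbers compound 2 stands lowest, with compound 1 the nearest at a markedly higher number; that gap lies beyond the usual scatter, so compound 2 counts as the stronger inhibitor of growth of the pair.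

Compound 3 `O=C1Nc2ccccc2/C1=C\c1c(Cl)n(CCCc2ccccc2)c2ccccc12` has not yet been measured in this assay. It is built from compound 2 by one change: hydrogen in place of chloro on an aromatic carbon. The chloro leaves an aromatic carbon of a six-membered aromatic ring of carbon only, part of a fused system of two rings, and a hydrogen takes its place.

Within the data shown here, no pair of measured compounds here differs in just one place, so there is no measured step to lean on. Removing a single chlorine is a small change, and the step of a 1.5-fold higher number from compound 2 to compound 3 (0.16 log units; within the scatter) is expected to be modest, toward a somewhat weaker inhibitor of growth, and may well not exceed the scatter. Compound 3 is expected to give about 3200 nM in this assay, with a likely range from 1300 nM to 8000 nM.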

Compound 3, concentration for 50% growth inhibition: 10000 nM
Estimate against measurement, compound 3: 3.1-fold (0.49 log units) below; the measured number lies above the stated range.
By their numbers in this assay, from the lowest: compound 2; then compounds 3 and 1 (each within the scatter of the next).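

In this assay, the change reads as a 4.6-fold higher number from compound 2 to compound 3 (0.66 log units; beyond the scatter). Among these compounds, this is the first measured step, and it shows that, with everything else held the same, hydrogen in place of chloro on this aromatic carbon gives a weaker inhibitor of growth, by more than repeated measurements would scatter. So this carbon of the six-membered aromatic ring is not a place where a chlorine can be removed without consequence in these cells, although a single pair shows this only for compounds carrying the 3-phenylpropyl-type chain of compound 2 and compound 3, and the data offer no measured account of why the chloro matters.

As far as these compounds go, whether another atom or group on this carbon, such as a fluoro, a bromo, a nitrile or an amine, would match the chloro, improve on it or behave like hydrogen stays open. Also open, from the compounds shown here alone, is whether the step keeps its size on another compound of the series, since compound 1 differs from both compound 2 and compound 3 in several places and cannot answer that.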